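A few compounds are considered here, and "the series" means these few. Any claim that something is new, unique, unknown or untested is made for them only; others in the source may bear on it.

Of the compounds shown here, two sharing one core have been measured in a functional assay on MCF7 cells (Homo sapiens) for antiproliferative activity, read by MTT assay, with a stated time of 48 h; on this read-out higher numbers stand for weaker inhibition and lower numbers for stronger inhibition. Compound 1 `O=[N+]([O-])c1cccc(-c2nn(-c3ccccc3)cc2C(Nc2nc3ccccc3s2)c2c(O)ccc3ccccc23)c1` gives 43900 nM, the higher of the two numbers and so the weaker inhibition, while compound 2 `Cc1ccc(-c2nn(-c3ccccc3)cc2C(Nc2nc3ccccc3s2)c2c(O)ccc3ccccc23)cc1` gives 13100 nM. Compound 3 `O=[N+]([O-])c1cccc(-c2nn(-c3ccccc3)cc2C(Nc2nc3ccc(Cl)cc3s2)c2c(O)ccc3ccccc23)c1` differs from compound 1 by one small change: chloro in place of hydrogen on an aromatic carbon. This turns the 1,3-benzothiazol-2-yl group into 6-chloro-1,3-benzothiazol-2-yl. For the measured compounds named here, only one measured step offers any guide, a 3.4-fold lower number from compound 1 to compound 2 (0.53 log units; beyond the scatter), and it is a different change, 4-methylphenyl in place of 3-nitrophenyl. Going by the values given here, no measured pair shows what chloro does on this core. That step is modest, so a step of similar size or smaller is expected in this assay. Going by these compounds, the direction stays open, with a slight lean towards a lower number, since compound 1 sits at the top of this small set with 43900 nM. For compound 3 the estimated value is 30000 nM, with an expected range from 10000 nM to 90000 nM. This estimate amounts to an expected 1.5-fold lower number from compound 1 to compound 3 (0.17 log units; within the scatter).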

Compound 3, half-maximal inhibitory concentration: 19700 nM
Estimate against measurement, compound 3: 1.5-fold (0.18 log units) above; the measured number falls inside the stated range.
By their numbers in this assay, from the lowest: compounds 2 and 3 (each within the scatter of the next); then compound 1.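

In this assay, replacing one hydrogen of the 1,3-benzothiazol-2-yl group with chloro brings a 2.2-fold lower number from compound 1 to compound 3 (0.35 log units; beyond the scatter), so this small change gives a modest but real gain in inhibition. The earlier step concerned the 3-nitrophenyl group, whereas this one shows that the number also responds at a second place in the molecule, a carbon of the six-membered ring of the fused system. A change of just one heavy atom here is enough to move the result beyond the usual scatter of repeated measurements, although the value stays in the same broad range. No measured evidence is available to explain why chloro at this carbon lowers the number.

The compounds shown leave open whether fluoro, methoxy or an amine on this same carbon would lower the number further, match chloro or raise it again. They also leave open whether chloro would bring a step of similar size and direction on the core of compound 2, which carries 4-methylphenyl in place of 3-nitrophenyl, or whether the two changes would not add up.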